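One Stereocentre Inverted on a Cyclohexylmethyl Compound

A few compounds are considered here, and "the series" means these few. Any claim that something is new, unique, unknown or untested is made for them only; others in the source may bear on it.

Compound 1 `O[C@H]1CO[C@H](COCc2ccccc2)[C@@H](OCc2ccccc2)[C@@H]1OCc1ccccc1`: 37900 nM
Compound 2 `O[C@@H]1[C@@H](OCc2ccccc2)[C@H](OCc2ccccc2)[C@@H](COCc2ccccc2)O[C@H]1CC1CCCCC1`: 4400 nM

Both values come from a functional assay on HOS cells (Homo sapiens) for antiproliferative activity, read by sulforhodamine B assay (a higher number here means a weaker inhibitor of growth, a lower number a stronger inhibitor of growth), where compound 2, at 4400 nM, holds the lower of the two numbers. Compound 3 `O[C@@H]1[C@@H](OCc2ccccc2)[C@H](OCc2ccccc2)[C@@H](COCc2ccccc2)O[C@@H]1CC1CCCCC1` has not yet been measured. Its relation to compound 2 is simple: the two compounds have the same atoms and bonds and differ only in configuration as drawn: 1 of 5 stereo elements differ; a stereocentre at a saturated ring carbon is drawn S in compound 2 and R in compound 3. A stereocentre at a saturated ring carbon is drawn S in compound 2 and R in compound 3.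

Going by the values given here, only one measured step exists, an 8.6-fold lower number from compound 1 to compound 2 (0.94 log units; beyond the scatter), and it records cyclohexylmethyl in place of hydrogen on a saturated ring carbon. Among the compounds with values here, it bears only indirectly, since no measured pair differs in configuration alone. The data therefore give no direction, and no step beyond the scatter is expected, although the range stays wide.

The expected change is a 1.3-fold higher number from compound 2 to compound 3 (0.10 log units; within the scatter). In this assay, compound 3 is estimated at 5500 nM, within an expected range of 2000 nM to 18000 nM.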

Compound 3, concentration for 50% growth inhibition: <= 20700 nM
Compound 3: only a limit was reported; the forecaster's own chance of this, stated with the estimate: 8%; the middle value does not contradict the limit.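

In this assay compound 3 gives only a limit, <= 20700 nM, and that is a limit and not a number. Going by these compounds alone, the step from compound 2 to compound 3 therefore cannot be read, even though this is the one pair here that isolates the inverted stereocentre: the fact that compounds 2 and 3 differ only in the configuration as drawn. Within the data shown here, the only readable new step is an at least 1.8-fold lower number from compound 1 to compound 3 (0.26 log units; that floor lies within the scatter), so the compound with cyclohexylmethyl drawn R adds a floor that cannot by itself be told from the scatter, whereas the S compound gave a step beyond it.

The compounds shown leave open whether the configuration at this saturated ring carbon changes growth inhibition at all. They also leave open how an amine or a longer chain in place of cyclohexylmethyl at this carbon would compare with compound 1.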